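Vero Cell Tolerance From Compound 3 to Compound 4

The source may report more compounds than this note shows. Statements on the series, on what has been measured and on what is new or still open speak of the compounds shown alone.

compound 1, `C[C@]1(CN2CCc3nc(-c4ccc(F)cc4)oc3C2)Cn2cc([N+](=O)[O-])nc2O1`: > 32 ug/mL
compound 2, `C[C@]1(CN2CCc3oc(-c4ccc(F)cc4)nc3C2)Cn2cc([N+](=O)[O-])nc2O1`: > 32 ug/mL
compound 3, `C[C@]1(CN2CCc3nc(C4CCCCC4)ccc3C2)Cn2cc([N+](=O)[O-])nc2O1`: "not determined" (no result reported)

In an ADME assay on Vero cells (Chlorocebus sabaeus) for cytotoxicity, read by MTT assay, with a stated time of 72 h (a lower number here means that less compound is tolerated, a higher number that more compound is tolerated), compound 1 returns only a limit, > 32 ug/mL. Compound 2 likewise returns a limit, > 32 ug/mL. Compound 3 returns "not determined" (no result reported) in this assay, so it stands nowhere on the scale shown; the only anchor is the limit of > 32 ug/mL in this assay, at which 2 of the 3 values shown sit. Compound 4, `C[C@]1(CN2CCc3nc(-c4cc(F)cc(F)c4)ccc3C2)Cn2cc([N+](=O)[O-])nc2O1`, differs from compound 3 in one place: 3,5-difluorophenyl in place of cyclohexyl on an aromatic carbon. Going by the values given here, no step between measured compounds exists to set the size of this change, and since both results so far are limits, no movement beyond the scatter is expected. Compound 4 is therefore expected to sit at about 40 ug/mL, within 12 ug/mL to 100 ug/mL, most probably again as a limit.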

Compound 4, half-maximal cytotoxic concentration: > 32 ug/mL
Compound 4 ended at the assay's limit; the forecaster's own chance of this, stated with the estimate: 75%; the middle value lies beyond the limit too.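

Compound 4 gives > 32 ug/mL, which is a limit. Going by these compounds alone, compound 3 has no reported result, and no step between compound 3 and compound 4 can be read. The compounds shown leave open where the half-maximal cytotoxic concentration of any of them lies.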